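The source may hold more compounds than are shown below. What is called first, only, known or untested is meant among the compounds shown, and "the series" means these compounds.

Compound 1 (`Nc1ccccc1NC(=O)c1ccc(CNC(=O)c2n[nH]cc2NC(=O)c2c(F)cccc2Cl)cc1`): 3630 nM
Compound 2 (`Nc1ccccc1NC(=O)c1ccc(CNC(=O)c2n[nH]cc2NC(=O)c2ccccc2Cl)cc1`): 6360 nM

Both compounds were tested in a functional assay on NCI-H460 cells (Homo sapiens) for inhibition, read by CCK-8 assay, with a stated time of 72 h; on this read-out lower numbers stand for stronger inhibition and higher numbers for weaker inhibition. Among the compounds with values here, compound 2 sits within the scatter of compound 1, the only other measured compound, so the pair gives it no distinct rank. Compound 3 (`Nc1ccccc1NC(=O)c1ccc(CNC(=O)c2n[nH]cc2NC(=O)c2ccccc2)cc1`) is the next case, and the change from compound 2 is hydrogen in place of chloro on an aromatic carbon with hydrogen in place of chloro on an aromatic carbon. Within the data shown here, one measured step bears on this: a 1.8-fold higher number from compound 1 to compound 2 (0.24 log units; within the scatter) likewise swaps a halogen for hydrogen, though the halogen lost there is fluoro rather than chloro. It is a single example and a weak guide. The expected step (a 1.3-fold higher number from compound 2 to compound 3 (0.13 log units; within the scatter)) is therefore small, leaning towards a higher number and not expected to exceed the scatter. For compound 3 the estimated value is 8500 nM with an expected range from 3500 nM to 20000 nM in this read-out.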

Compound 3, half-maximal inhibitory concentration: 6320 nM
Estimate against measurement, compound 3: 1.3-fold (0.13 log units) above, within the range that was stated.
By their numbers in this assay, from the lowest: compounds 1, 3 and 2 (each within the scatter of the next).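

In this assay, the change from 2-chlorophenyl to phenyl (a 1.0-fold lower number from compound 2 to compound 3 (0.00 log units; within the scatter)) shows that the chloro, ortho to a large group, can be replaced by hydrogen with the result staying within the scatter. The wider change of phenyl in place of 2-chloro-6-fluorophenyl (a 1.7-fold higher number from compound 1 to compound 3 (0.24 log units; within the scatter)) is also within the scatter, so the three compounds show no measurable dependence on either halogen, even when both are absent. No available evidence accounts for this result.

The compounds shown leave open whether a different kind of group at this place, such as a methoxy, an amine or a carboxylic acid, would move the number beyond the scatter. They also leave open whether the same replacements would hold on a different core.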